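This account rests on a few compounds, and the source may have more. Where it says the series, first, only, none or still open, it means among the compounds named here.

Compound 2, with the structure `COc1ccc(NC(=O)Nc2cc(C)nc3ccccc23)cc1Cl`, stands in an ADME assay on HepG2 cells (Homo sapiens) for cytotoxicity, with a stated time of 72 h (a lower number here means that less compound is needed, a higher number that more compound is needed for the effect), at > 25000 nM, which is a limit of the assay and not a number. The two neighbours that differ from it in one place stand the same way. Compound 1, with the structure `COc1ccc(NC(=O)Nc2cc(C)nc3ccccc23)cc1OC`, gives in this assay > 25000 nM, again a limit. Compound 3, with the structure `COc1ccc(NC(=O)Nc2cc(C)nc3ccccc23)cc1F`, gives in this assay > 25000 nM, also a limit. Accordingly the steps among them cannot be sized: a step that the two limits leave unreadable from compound 1 to compound 2, a step that the two limits leave unreadable from compound 1 to compound 3 and a step that the two limits leave unreadable from compound 2 to compound 3. What unites them is the limit of > 25000 nM in this assay, at which 3 of the 3 values shown sit.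

Compound 4, with the structure `Cc1cc(NC(=O)Nc2cccc(Cl)c2)c2ccccc2n1`, has not yet been measured in this assay. Its difference from compound 2 is hydrogen in place of methoxy on an aromatic carbon. Among the measured compounds shown here, none of the three measured steps bears a readable size on this change, so no direction can be drawn from them; the only evidence is that every measured value sits at the limit. Compound 4 is therefore expected to sit near that same limit in this assay, with an estimate of 25000 nM and a range from 8000 nM to 80000 nM. That estimate means an expected step of a number no higher from compound 2 to compound 4 (the limit leaves the size open), with a high chance that only a limit is reported again.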

Compound 4, half-maximal effective concentration: 19000 nM
For compound 4 the middle estimate is 1.3-fold (0.12 log units) above the measured one; measured number inside the range.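

Compound 4 is the only compound shown that gives a number rather than a limit in this assay, at 19000 nM, so this change yields the first readable value in the set. Hydrogen in place of methoxy on this aromatic carbon, ortho to a chloro group and para to a large group, gives an at least 1.3-fold lower number from compound 2 to compound 4 (0.11 log units; that floor lies within the scatter), and this is the only step shown that has even a floor, while the steps among the earlier compounds cannot be read. The floor does not establish a real drop, and the full size of the step stays unknown, as compound 2 remains at a limit, like most of the set: the limit of > 25000 nM in this assay, at which 3 of the 4 values shown sit.

The compounds shown leave open whether the same change would give a similar result with fluoro in place of chloro, and how far compound 4 truly lies from compound 2. They also leave open what an amine, a hydroxyl group or a longer chain such as ethoxy on this aromatic carbon would give in this assay.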